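A few compounds are considered here, and "the series" means these few. Any claim that something is new, unique, unknown or untested is made for them only; others in the source may bear on it.

Working notes on the series. In a functional assay on A-375 cells (Homo sapiens) for inhibition, read by MTT assay, with a stated time of 4 days (on this read-out higher numbers stand for weaker inhibition and lower numbers for stronger inhibition), compound 1 (`CN1C[C@@H]2C[C@H]1CN2c1ccc(-c2ccnc3c(-c4cccc5[nH]ncc45)c(-c4ccncc4)nn23)cc1`) gives 202 nM, and compound 3 (`CN1C[C@@H]2C[C@H]1CN2c1ccc(-c2ccnc3c(-c4cccc5[nH]ncc45)c(-c4ccncc4)nn23)c(F)c1F`) gives 107 nM. These two values lie within the usual scatter of each other. Compound 2 (`CN1C[C@@H]2C[C@H]1CN2c1ccc(-c2ccnc3c(-c4cccc5[nH]ncc45)c(-c4ccncc4)nn23)cc1F`) has no single number to stand on: its entry in this assay reads "not determined" (no result reported), so the starting point of the step below cannot be placed against the other two compounds.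

Compound 4 (`CN1C[C@@H]2C[C@H]1CN2c1cc(F)c(-c2ccnc3c(-c4cccc5[nH]ncc45)c(-c4ccncc4)nn23)cc1F`) is still unmeasured. The change is fluoro in place of hydrogen on an aromatic carbon, ortho to a large group and para to a fluoro group.

Going by the values given here, no measured pair isolates a single change of this kind. In this assay no step beyond the scatter is expected and no direction is favoured, since compound 1 at 202 nM and compound 3 at 107 nM sit within the scatter of each other. For compound 4 the estimated value is 130 nM, with an expected range of 60 nM to 300 nM.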

Compound 4, half-maximal inhibitory concentration: 87 nM
Estimate against measurement, compound 4: 1.5-fold (0.17 log units) above; low and high end bracket the measured number.
By their numbers in this assay, from the lowest: compounds 4, 3 and 1 (each within the scatter of the next, the first and the last beyond it).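

No step can be read from compound 2 to compound 4: in this assay compound 2 has no single value, while compound 4 gives 87 nM. The compounds shown leave open what fluoro in place of hydrogen does at this place, ortho to a large group and para to a fluoro group. No further data here bear on this result.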